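The source may report more compounds than this note shows. Statements on the series, on what has been measured and on what is new or still open speak of the compounds shown alone.

In a functional assay on SW1573 cells (Homo sapiens) for antiproliferative activity, read by sulforhodamine B assay, with a stated time of 48 h (on this read-out lower numbers stand for stronger inhibition of growth and higher numbers for weaker inhibition of growth), three compounds built on a shared core have been measured. Compound 1 `CC(C)(C)[Si](C)(C)O[C@@H]1CCCO[C@@H]1COCC(=O)O` gives > 100000 nM, which is a limit and not a number. Compound 3 `CC(C)(C)[Si](C)(C)O[C@@H]1CCCO[C@@H]1CO/C=C/CO` gives > 100000 nM, which is also a limit. Compound 3 therefore stands at the limit of > 100000 nM in this assay, at which 2 of the 3 values shown sit. Only compound 2 `C=CCOC[C@H]1OCCC[C@H]1O[Si](C)(C)C(C)(C)C` gives a true number, 18000 nM. Two measured steps are beyond the scatter: an at least 5.5-fold lower number from compound 1 to compound 2 (0.74 log units; beyond the scatter) and an at least 5.5-fold higher number from compound 2 to compound 3 (0.74 log units; beyond the scatter). The third, a step that the two limits leave unreadable from compound 1 to compound 3, cannot be read.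

Compound 4 `COC(=O)CCOC[C@H]1OCCC[C@H]1O[Si](C)(C)C(C)(C)C` brings a new change: 2-(methoxycarbonyl)ethyl in place of 3-hydroxyprop-1-en-1-yl on an oxygen on a saturated carbon. Among the measured compounds shown here, no measured step makes this exact swap. Compound 4 has neither the carboxy of compound 1 nor the hydroxy of the 3-hydroxyprop-1-en-1-yl group of compound 3, and both of those compounds sit at the limit. A modest move towards a lower number is therefore expected, smaller than or similar to the step seen with compound 2, though compound 4 may stay at the limit. The expected change is an at least 2.5-fold lower number from compound 3 to compound 4 (0.39 log units; beyond the scatter). For compound 4 the estimated value is 40000 nM, with an expected range of 12000 nM to 100000 nM.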

Compound 4, concentration for 50% growth inhibition: > 100000 nM
Compound 4 gave a limit, no number; the forecaster's own chance of this, stated with the estimate: 40%; middle value at least 2.5-fold (0.39 log units) from the limit.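

In this assay compound 4 gives > 100000 nM, which is a limit and not a number. Replacing vinyl with (methoxycarbonyl)methyl on a saturated chain carbon bound to an oxygen on a saturated carbon gives an at least 5.5-fold higher number from compound 2 to compound 4 (0.74 log units; beyond the scatter), so a chain end with 0 hydrogen-bond donors does not by itself keep the measurable growth inhibition of compound 2. The steps linking compound 4 to compound 1 and compound 3 cannot be read, and compound 2 remains the only one of these compounds with a true number: the limit of > 100000 nM in this assay, at which 3 of the 4 values shown sit.

On these data alone, how compound 1, compound 3 and compound 4 rank against one another stays open. As far as these compounds go, it also stays open whether a saturated propyl chain or a chain ending in an amine on this oxygen would give a true number.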